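Kinetic solubility in a quinoline ether amide series

A few compounds are considered here, and "the series" means these few. Any claim that something is new, unique, unknown or untested is made for them only; others in the source may bear on it.

Measured compounds and values:
compound 1 `COc1ccc2nc(C)cc(OCC(=O)Nc3cc(C)cc(C)c3)c2c1`: 26000 nM
compound 2 `Cc1cc(C)cc(NC(=O)COc2cc(C)nc3ccc(C)cc23)c1`: 83000 nM
compound 3 `COc1cccc(NC(=O)COc2cc(C)nc3ccc(OC)cc23)c1`: 35000 nM

In a physicochemical assay for solubility, in phosphate buffer, measured as kinetic solubility, with a stated time of 1 h, at pH 7.4 (a lower number here means a less soluble compound, a higher number a more soluble compound), compound 3 stands second highest of the three, near compound 1 and further from compound 2. The two known steps are a 3.2-fold higher number from compound 1 to compound 2 (0.50 log units; beyond the scatter) and a 1.3-fold higher number from compound 1 to compound 3 (0.13 log units; within the scatter). Compound 4 `COc1ccc2nc(C)cc(OCC(=O)Nc3ccc(Cl)cc3Cl)c2c1` differs from compound 3 by 2,4-dichlorophenyl in place of 3-methoxyphenyl on an amide-type nitrogen, the entering group carrying 0 hydrogen-bond acceptors where the leaving group carried 1. For the measured compounds named here, only the step from compound 1 to compound 3 concerns the group on the amide-type nitrogen, and it stayed within the scatter; no measured step involves chlorine. Compound 4 is therefore expected to give a value near that of compound 3, with a small downward lean, a 1.8-fold lower number from compound 3 to compound 4 (0.24 log units; within the scatter), estimated at 20000 nM (range 6000 nM to 60000 nM).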

Compound 4, solubility: 20500 nM
Estimate against measurement, compound 4: 1.0-fold (0.01 log units) below; measured number inside the range.
By their numbers in this assay, from the lowest: compounds 4, 1 and 3 (each within the scatter of the next); then compound 2.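

In this assay, 2,4-dichlorophenyl on the amide-type nitrogen gives a 1.7-fold lower number from compound 3 to compound 4 (0.23 log units; within the scatter) and a 1.3-fold lower number from compound 1 to compound 4 (0.10 log units; within the scatter). With the core of compound 1 held fixed, three substituted phenyl groups at this place, including the first carrying chlorine and no hydrogen-bond acceptor, now lie within the scatter of one another. No data are at hand to explain this.

Still open, from the compounds shown here alone, is whether an amine or a carboxylic acid on the phenyl ring, or a longer alkyl chain in its place, would move this assay beyond the scatter. Also open, going by these compounds, is whether a 3.2-fold higher number from compound 1 to compound 2 (0.50 log units; beyond the scatter) would carry over to the 2,4-dichlorophenyl amide.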